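The source may report more compounds than this note shows. Statements on the series, on what has been measured and on what is new or still open speak of the compounds shown alone.

In an ADME assay on cells for inhibition of cytochrome P450 11B1, mitochondrial (Homo sapiens), read by HTRF (a lower number here means a stronger inhibitor, a higher number a weaker inhibitor), two compounds have been measured so far. Compound 1 `CCC(=O)N[C@@H]1CCCc2c1cncc2N1CCc2cc(Cl)ccc2C1=O` gives 3330 nM and stands lowest of the two. Compound 2 `N#Cc1ccc2c(c1)CN(c1cccnc1)C2=O` gives 15500 nM, a gap beyond the scatter. Compound 3 `CS(=O)(=O)N[C@@H]1CCCc2c1cncc2N1CCc2cc(Cl)ccc2C1=O` differs from compound 1 in one place: methylsulfonyl in place of propanoyl on an amine nitrogen. For the measured compounds named here, no measured pair shows this change, so the size of its step cannot be read from the data; only a small shift in this assay, in either direction and probably within the scatter, is expected. Compound 3 is therefore expected near 3000 nM, with a range from 1200 nM to 8000 nM, which means an expected step of a 1.1-fold lower number from compound 1 to compound 3 (0.05 log units; within the scatter).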

Compound 3, half-maximal inhibitory concentration: 5150 nM
Compound 3: middle estimate off by 1.7-fold (0.23 log units), on the low side, within the range that was stated.
By their numbers in this assay, from the lowest: compounds 1 and 3 (each within the scatter of the next); then compound 2.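

In this assay, methylsulfonyl in place of propanoyl on an amine nitrogen gives a 1.5-fold higher number from compound 1 to compound 3 (0.19 log units; within the scatter), the first step read at this position. The two compounds stand within the scatter of each other, so this pair shows no separation between the propanoylamino and methanesulfonamido groups here. Nothing available explains this result.

On these data alone, what a longer acyl chain, a urea or a free amine on this nitrogen would give stays open. So does whether this change would give a similar step on a different core.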